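Extending the aryl ether of a uracil-derived triphosphate agonist

The source may report more compounds than this note shows. Statements on the series, on what has been measured and on what is new or still open speak of the compounds shown alone.

Measured compounds:
- compound 1, `O=c1[nH]/c(=N\OCCCc2ccc(I)cc2)ccn1[C@@H]1O[C@H](COP(=O)(O)OP(=O)(O)OP(=O)(O)O)[C@@H](O)[C@H]1O`: 187 nM
- compound 2, `COc1ccc(CCCO/N=c2/ccn([C@@H]3O[C@H](COP(=O)(O)OP(=O)(O)OP(=O)(O)O)[C@@H](O)[C@H]3O)c(=O)[nH]2)cc1`: 47 nM

Compound 2 stands at the lowest of the two numbers in a functional assay on 1321-N1 cells for agonist activity at P2Y purinoceptor 2 (Homo sapiens), read by scintillation counting and inositol phosphate accumulation; a higher number here means that more compound is needed for the effect, a lower number that less compound is needed; its nearest neighbour is compound 1, and the step of a 4.0-fold lower number from compound 1 to compound 2 (0.60 log units; beyond the scatter) lies beyond the scatter. Compound 3, `C#CCCNC(=O)COc1ccc(CCCO/N=c2/ccn([C@@H]3O[C@H](COP(=O)(O)OP(=O)(O)OP(=O)(O)O)[C@@H](O)[C@H]3O)c(=O)[nH]2)cc1`, has not been measured in this assay. It differs from compound 2 by a group of 7 heavy atoms (5 carbon, 1 nitrogen, 1 oxygen; no ring) in place of a hydrogen atom, on a saturated chain carbon bound to an oxygen on an aromatic ring; the added chain is the one described under the counted difference, carrying an amide and a terminal alkyne.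

Within the data shown here, only one measured step exists, the exchange of iodo for methoxy on the aromatic ring that gave a 4.0-fold lower number from compound 1 to compound 2 (0.60 log units; beyond the scatter). That change touches the same aromatic position but is of a different kind from the lengthening in compound 3, so it gives only a weak indication. The anchoring, including the aromatic ring and the whole triphosphate portion, is kept unchanged. Compound 3 is therefore expected to show a step of a 1.5-fold higher number from compound 2 to compound 3 (0.17 log units; within the scatter), within or near the scatter, with an estimate of 70 nM and a range from 20 nM to 250 nM.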

Compound 3, half-maximal effective concentration: 109 nM
Compound 3: middle estimate off by 1.6-fold (0.19 log units), on the low side; measured number inside the range.
By their numbers in this assay, from the lowest: compound 2; then compounds 3 and 1 (each within the scatter of the next).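

In this assay, the carbon of the methoxy group of compound 2 accepts a long chain carrying an amide and a terminal alkyne, at a modest cost: a 2.3-fold higher number from compound 2 to compound 3 (0.37 log units; beyond the scatter). This is the first change shown at this saturated chain carbon bound to an oxygen on an aromatic ring, and the step shows that agonist activity survives a group of this size there, rather than being lost. Against the iodo compound, the result is a tie and not a gain (a 1.7-fold lower number from compound 1 to compound 3 (0.23 log units; within the scatter)), so the advantage of the methoxy group over iodine is largely given back, while compound 3 remains a nanomolar agonist in this assay. Nothing given here accounts for the size of this step.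

The compounds shown do not separate the contribution of the amide from that of the terminal alkyne, nor do they show whether a shorter chain, a longer chain or one ending in a carboxylic acid or an amine would fare differently. They also leave open whether the same chain would be accepted on a different part of the molecule.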